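A Methyl Group Tested on Two Related Cores

This account rests on a few compounds, and the source may have more. Where it says the series, first, only, none or still open, it means among the compounds named here.

Compound 1 `COc1cc(-c2cc(COCc3cn(Cc4cc(-c5ccccc5)cnc4Cl)nn3)on2)cc(OC)c1OC` and compound 2 `COc1cc(-c2cc(COCc3cn(Cc4cc(-c5ccc(C)cc5)cnc4Cl)nn3)on2)cc(OC)c1OC` share one core and differ in a single change, (methyl in place of hydrogen on an aromatic carbon). In a functional assay on DU-145 cells (Homo sapiens) for cytotoxicity, read by MTT assay, with a stated time of 48 h (a higher number here means a weaker inhibitor, a lower number a stronger inhibitor), compound 1 gives 78500 nM, and compound 2 gives 37300 nM, so this change made a 2.1-fold lower number from compound 1 to compound 2 (0.32 log units; beyond the scatter). Compound 3 `COc1cc(C2=NOC(COCc3cn(Cc4cc(-c5ccccc5)cnc4Cl)nn3)C2)cc(OC)c1OC` is built on a different core; the difference between the two cores is not broken down here. In this assay compound 3 gives 11400 nM, the lowest of the three numbers. Compound 4 `COc1cc(C2=NOC(COCc3cn(Cc4cc(-c5ccc(C)cc5)cnc4Cl)nn3)C2)cc(OC)c1OC` has not yet been measured. For the measured compounds named here, it differs from compound 3 by methyl in place of hydrogen on an aromatic carbon, which is the same kind of change as the one between compound 1 and compound 2, at a place described in the same words. The expectation rests on that earlier pair, where the change made a 2.1-fold lower number from compound 1 to compound 2 (0.32 log units; beyond the scatter). A step of similar size is expected here: a 2.1-fold lower number from compound 3 to compound 4 (0.32 log units; beyond the scatter). In this assay, going by the values given here, compound 4 is therefore estimated at 5500 nM, with a range from 2500 nM to 12000 nM, kept wide because only one earlier example of this change on a different core is available.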

Compound 4, half-maximal inhibitory concentration: 13100 nM
Estimate against measurement, compound 4: 2.4-fold (0.38 log units) below; the whole stated range lies below it.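

In this assay, the methyl on the core of compound 3 gave a step that stays within the usual scatter of repeated measurements: a 1.1-fold higher number from compound 3 to compound 4 (0.06 log units; within the scatter). The earlier step on the other core lay just beyond that scatter, yet the two steps cannot be told apart: the same change on two cores in this assay, a 2.1-fold lower number (0.32 log units; beyond the scatter) from compound 1 to compound 2 and a 1.1-fold higher number (0.06 log units; within the scatter) from compound 3 to compound 4, 2.4-fold (0.38 log units) apart, within the scatter of two such steps. This shows no firm sign that the change from phenyl to 4-methylphenyl behaves differently on the two cores, but it does not show that the change carries over either, since the small gain on the first core did not reappear beyond the scatter on the second and one pair per core is a thin basis for any rule.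

The compounds shown leave open what an ethyl, a methoxy, an amine or a carboxylic acid would do in the place of the methyl. They also leave open whether any such group would give steps that agree on both cores, which would say more about transfer than this single small change can.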